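The source may hold more compounds than are shown below. What is called first, only, known or untested is meant among the compounds shown, and "the series" means these compounds.

Among the measured compounds shown here, in a functional assay on MDA-MB-231 cells (Homo sapiens) for inhibition, read by MTT assay, with a stated time of 72 h (on this read-out higher numbers stand for weaker inhibition and lower numbers for stronger inhibition), compound 1 (`CC(C)=CCC[C@H](C)c1ccc(C)c(CNCC2CCNCC2)c1O`) gives 18300 nM, the higher of the two numbers measured so far. Compound 2 (`CC(C)=CCC[C@H](C)c1ccc(C)c2c1OCN(CCCCCO)C2`) gives 5400 nM, so compound 1 is the weaker inhibitor of the pair, by a margin beyond the usual scatter of repeat measurements. Compound 3 (`CC(C)=CCC[C@H](C)c1ccc(C)c(CNCCCCC(=O)O)c1O`) has not yet been measured. It differs from compound 1 in one place: 3-carboxypropyl in place of piperidin-4-yl on a saturated chain carbon bound to an amine nitrogen. In words, 3-carboxypropyl stands in place of piperidin-4-yl on a saturated chain carbon bound to an amine nitrogen. For the measured compounds named here, no measured pair shows this change, so the data give no direct guide. In this assay, a small move towards weaker inhibition is expected, possibly not beyond the scatter. The expected step is a 1.5-fold higher number from compound 1 to compound 3 (0.18 log units; within the scatter). For compound 3 the estimated value is 28000 nM, with an expected range of 10000 nM to 75000 nM.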

Compound 3, half-maximal inhibitory concentration: > 50000 nM
Compound 3 ended at the assay's limit (the forecaster's own chance of this, stated with the estimate: 25%); middle value at least 1.7-fold (0.25 log units) from the limit.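

In this assay, 3-carboxypropyl in place of piperidin-4-yl on a saturated chain carbon bound to an amine nitrogen gives an at least 2.7-fold higher number from compound 1 to compound 3 (0.43 log units; beyond the scatter), the first step read at this position, and it lies beyond the scatter. Compound 3 gives > 50000 nM, which is a limit of the assay and not a number. The position is therefore not indifferent to this change, since inhibition weakens when the ring gives way to this chain, but the full size of the loss stays unread: the limit of > 50000 nM in this assay, at which 1 of the 3 values shown sits.

This single change does not separate the loss of the ring from the arrival of the carboxylic acid. From the compounds shown here alone, whether a chain ending in an amine, or a methyl ester in place of the carboxylic acid, would keep inhibition at the level of compound 1 remains open.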